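The source may hold more compounds than are shown below. What is called first, only, known or untested is meant among the compounds shown, and "the series" means these compounds.

In a functional assay, with a stated time of 30 min, in the absence of a further agent (a higher number here means a weaker inhibitor, a lower number a stronger inhibitor), compound 1 `O=C(Nc1nnc(-c2cccc(O)c2O)s1)c1ccc(Cl)cc1` gives 30200 nM. Compound 2 `Cc1ccc(C(=O)Nc2nnc(-c3ccc(O)c(O)c3)s2)cc1` gives 34000 nM, and compound 3 `O=C(Nc1nnc(-c2ccc(O)c(O)c2)s1)c1ccc(Cl)cc1` gives 53000 nM, so compound 1 stands within the scatter of both. Compound 4 `Cc1ccc(C(=O)Nc2nnc(-c3cccc(O)c3O)s2)cc1` keeps the core of compound 1 and turns 4-chlorophenyl into 4-methylphenyl: methyl in place of chloro on an aromatic carbon. Within the data shown here, one measured step bears on this, the same exchange run the other way on a different arrangement of the two hydroxyl groups: a 1.6-fold higher number from compound 2 to compound 3 (0.19 log units; within the scatter). That step stays within the scatter, so no change beyond the scatter is expected in this assay. Compound 4 is estimated at 26000 nM, with an expected range of 13000 nM to 52000 nM. The expected step is a 1.2-fold lower number from compound 1 to compound 4 (0.07 log units; within the scatter).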

Compound 4, half-maximal inhibitory concentration: 27100 nM
Estimate against measurement, compound 4: 1.0-fold (0.02 log units) below; measured number inside the range.
By their numbers in this assay, from the lowest: compounds 4, 1, 2 and 3 (each within the scatter of the next).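

In this assay, methyl in place of chloro at this position of the 4-chlorophenyl group also leaves the number within the scatter on the core of compound 1 (a 1.1-fold lower number from compound 1 to compound 4 (0.05 log units; within the scatter)). The exchange can now be read on two arrangements of the two hydroxyl groups, and neither core separates chloro from methyl: the same change on two cores in this assay, a 1.6-fold higher number (0.19 log units; within the scatter) from compound 2 to compound 3 and a 1.1-fold higher number (0.05 log units; within the scatter) from compound 4 to compound 1, 1.4-fold (0.15 log units) apart, within the scatter of two such steps. Chloro and methyl are the only groups shown at this position, so it remains open whether an amine, a carboxylic acid or a longer chain there would shift the number beyond the scatter.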